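Working notes: isopropyl to ethyl on the shared core

This account rests on a few compounds, and the source may have more. Where it says the series, first, only, none or still open, it means among the compounds named here.

Values so far in an ADME assay on MT4 cells (Homo sapiens) for cytotoxicity, read by MTT assay (on this read-out lower numbers stand for higher toxicity in this test and higher numbers for lower toxicity in this test), for three compounds:
- compound 1 (`Cc1ccc(CC2C(=O)N(O)C(=O)c3ccccc32)cc1`) gives 5500 nM
- compound 2 (`CC(C)C1C(=O)N(O)C(=O)c2ccccc21`) gives 123000 nM
- compound 3 (`O=c1c2ccccc2c(Cc2ccccc2)c(O)n1O`) gives 88000 nM

Compound 2 at 123000 nM and compound 3 at 88000 nM lie within the scatter of each other, and compound 1 lies beyond the scatter below compound 2.

Next is compound 4 (`CCC1C(=O)N(O)C(=O)c2ccccc21`), which differs from compound 2 (hydrogen in place of methyl on a saturated chain carbon bound to a saturated chain carbon and a saturated ring carbon) by hydrogen in place of methyl on a saturated chain carbon bound to a saturated chain carbon and a saturated ring carbon. The same difference reads isopropyl to ethyl.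

Among the compounds with values here, no measured pair shows this change directly, so the expectation in this assay is no step beyond the scatter, and it rests on compound 2 at 123000 nM as the closest neighbour. The low side stays wider since compound 1 at 5500 nM shows how far the shared core can fall. The estimated step of a 1.2-fold lower number from compound 2 to compound 4 (0.07 log units; within the scatter) is expected to stay within the scatter. Compound 4 is estimated at 105000 nM (expected range 45000 nM to 190000 nM).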

Compound 4, half-maximal cytotoxic concentration: 250000 nM
For compound 4 the middle estimate is 2.4-fold (0.38 log units) below the measured one; measured number above the stated range.
By their numbers in this assay, from the lowest: compound 1; then compounds 3 and 2 (each within the scatter of the next); then compound 4.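

Within the data shown here, removing one methyl, isopropyl to ethyl, gives a 2.0-fold higher number from compound 2 to compound 4 (0.31 log units; beyond the scatter) in this assay, the first reading of a single change at this position, and it points towards lower toxicity in this test. Methyl in place of 4-methylphenyl on the saturated chain carbon bound to a saturated ring carbon gives a 45-fold higher number from compound 1 to compound 4 (1.66 log units; beyond the scatter) and is by far the larger step, so the 4-methylphenyl-bearing side chain of compound 1 accounts for much more of the spread on this shared core than the loss of one methyl does. Nothing at hand gives a reason for either step.

Going by these compounds, whether the trend from compound 2 to compound 4 continues with a lone methyl or hydrogen at this position remains open. On these data alone, it is also open where a longer chain such as n-butyl, or a chain ending in an amine or a carboxylic acid, would fall relative to compound 4 and compound 1.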